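Fluoro in place of methyl: what to expect for compound 3

The compounds below may be only part of what the source reports. "The series", "measured", "known", "first", "only" and "open" are said of these compounds alone.

Compound 1 `CCN(CC)C(=O)CN(c1ccc(C)cc1)S(=O)(=O)c1cccc(Cl)c1` carries a chloro group; in a functional assay on CHO cells for inhibition of Orexin/Hypocretin receptor type 1 (Homo sapiens), read by FLIPR and calcium flux (on this read-out higher numbers stand for weaker inhibition and lower numbers for stronger inhibition), compound 1 gives > 10000 nM, which is a limit of the assay and not a number. Compound 2 `CCN(CC)C(=O)CN(c1ccc(C)cc1)S(=O)(=O)c1cccc(C)c1` has methyl in place of chloro on an aromatic carbon; in this assay compound 2 gives > 10000 nM, again a limit rather than a number. The step that the two limits leave unreadable from compound 1 to compound 2 is therefore unreadable in size, because both values sit at the limit of > 10000 nM in this assay, at which 2 of the 2 values shown sit. Compound 2 thus stands at the edge of what this assay reports, with no ordering against compound 1 possible. Compound 3 `CCN(CC)C(=O)CN(c1ccc(C)cc1)S(=O)(=O)c1cccc(F)c1` differs from compound 2 by fluoro in place of methyl on an aromatic carbon. For the measured compounds named here, the only measured step is unreadable, so no direction or size can be read from it for this change. Compound 3 is expected to remain at the same limit, with an estimate of 15000 nM spanning 5000 nM to 50000 nM, meaning an expected step that the limit leaves unreadable from compound 2 to compound 3 that is not resolvable.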

Compound 3, half-maximal inhibitory concentration: > 10000 nM
Compound 3 gave a limit, no number (the forecaster's own chance of this, stated with the estimate: 85%); the middle value does not contradict the limit.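

In this assay compound 3 gives > 10000 nM, a limit and not a number. No step among compound 1, compound 2 and compound 3 can be read: the limit of > 10000 nM in this assay, at which 3 of the 3 values shown sit.

Going by these compounds, how chloro, methyl and fluoro at this place rank against one another stays open.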